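Swapping cyano for methoxy on the aryl amine arm

A few compounds are considered here, and "the series" means these few. Any claim that something is new, unique, unknown or untested is made for them only; others in the source may bear on it.

Among the compounds with values here, compound 3 `Cc1cc(Nc2cc(N3CCN(C)CC3)nc(Nc3ccc(C#N)cc3)n2)n[nH]1` gives 372 nM in a functional assay on MCF7 cells (Homo sapiens) for antiproliferative activity, read by CCK-8 assay, with a stated time of 72 h (on this read-out higher numbers stand for weaker inhibition and lower numbers for stronger inhibition), the lowest of the three numbers measured so far. Compound 2 `Cc1cc(Nc2cc(N3CCN(C)CC3)nc(Nc3cccc([N+](=O)[O-])c3)n2)n[nH]1` gives 642 nM, and the gap a 1.7-fold lower number from compound 2 to compound 3 (0.24 log units; within the scatter) lies within the scatter. Compound 1 `Cc1cc(Nc2cc(N3CCN(C)CC3)nc(Nc3ccc(Cl)cc3)n2)n[nH]1` gives 840 nM, and the step of a 2.3-fold lower number from compound 1 to compound 3 (0.35 log units; beyond the scatter) is the only one that clears the scatter. Compound 4 `COc1ccc(Nc2nc(Nc3cc(C)[nH]n3)cc(N3CCN(C)CC3)n2)cc1` differs from compound 3 by methoxy in place of cyano on an aromatic carbon. The step of a 2.3-fold lower number from compound 1 to compound 3 (0.35 log units; beyond the scatter) bears most directly on this, since it also changes the group on that carbon, and it was modest. Within the data shown here, no measured compound carries methoxy, so the direction is open; a small rise toward the range of compound 1 seems plausible, with the expected step of a 1.6-fold higher number from compound 3 to compound 4 (0.21 log units; within the scatter). Compound 4 is therefore estimated at 600 nM, likely between 250 nM and 1500 nM.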

Compound 4, half-maximal inhibitory concentration: 2750 nM
Compound 4: middle estimate off by 4.6-fold (0.66 log units), on the low side; measured number above the stated range.
By their numbers in this assay, from the lowest: compounds 3, 2 and 1 (each within the scatter of the next, the first and the last beyond it); then compound 4.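

Methoxy on this aromatic carbon gives the first clear loss among these compounds in this assay: the number climbs by a 7.4-fold higher number from compound 3 to compound 4 (0.87 log units; beyond the scatter) and also by a 4.3-fold higher number from compound 2 to compound 4 (0.63 log units; beyond the scatter) and by a 3.3-fold higher number from compound 1 to compound 4 (0.52 log units; beyond the scatter). Compound 4 is thus the weakest of the four, and the group at this place can shift the number further than compound 1, compound 2 and compound 3 alone suggested. No measured evidence here explains the rise. From the compounds shown here alone, whether an amine or a carboxylic acid on this carbon would land nearer compound 3 or compound 4 stays open.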